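Swapping the Ester Group: What Cytotoxicity to Expect

The compounds below may be only part of what the source reports. "The series", "measured", "known", "first", "only" and "open" are said of these compounds alone.

Three esters sharing one core have been tested in an ADME assay on HepG2 2.2.15 cells (Homo sapiens) for cytotoxicity; on this read-out higher numbers stand for lower toxicity in this test and lower numbers for higher toxicity in this test. Compound 1 `COCC(=O)OCCc1c(-c2ccccc2Cl)c2cc(Cl)ccc2[nH]c1=O` gives 74000 nM. Compound 2 `O=C(OCCc1c(-c2ccccc2Cl)c2cc(Cl)ccc2[nH]c1=O)c1cccnc1` gives 170000 nM. For compound 3 `O=C(OCCc1c(-c2ccccc2Cl)c2cc(Cl)ccc2[nH]c1=O)c1cccs1` only a limit of the assay is known, > 1700000 nM. Compound 3 thus stands at the top of the three, its reading being (the limit of > 1700000 nM in this assay, at which 1 of the 3 values shown sits). Compound 4 `O=C(/C=C/c1ccc(C(F)(F)F)cc1)OCCc1c(-c2ccccc2Cl)c2cc(Cl)ccc2[nH]c1=O` differs from compound 3 in one place: 2-(4-(trifluoromethyl)phenyl)ethenyl in place of thiophen-2-yl on a carbonyl carbon. Going by the values given here, the steps that bear on this change swap the group on the same carbonyl carbon: an at least 22-fold higher number from compound 1 to compound 3 (1.36 log units; beyond the scatter) and an at least 10-fold higher number from compound 2 to compound 3 (1.00 log units; beyond the scatter), both large, and also a 2.3-fold higher number from compound 1 to compound 2 (0.36 log units; beyond the scatter). Such swaps have moved this read-out widely, so a sizeable step is expected, more likely downward from a limit; the estimate is an at least 5.6-fold lower number from compound 3 to compound 4 (0.75 log units; beyond the scatter). Compound 4 is therefore expected to give 300000 nM, within 70000 nM to 1700000 nM.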

Compound 4, half-maximal cytotoxic concentration: > 1400000 nM
Compound 4 was reported as a limit; the forecaster's own chance of this, stated with the estimate: 30%; middle value at least 4.6-fold (0.66 log units) from the limit.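

In this assay compound 4 is read only as a limit: the limit of > 1400000 nM in this assay, at which 1 of the 4 values shown sits.

The 2-(4-(trifluoromethyl)phenyl)ethenyl group on the carbonyl carbon, larger than thiophen-2-yl and carrying no sulfur, still leaves the number high, with an at least 8.2-fold higher number from compound 2 to compound 4 (0.91 log units; beyond the scatter) and an at least 18-fold higher number from compound 1 to compound 4 (1.27 log units; beyond the scatter). Compound 3 and compound 4 are both limits, so the step between them cannot be read.

Going by these compounds, how far the true values of compound 3 and compound 4 lie past their limits stays open. Also open, on these data alone, is how a plain saturated carbon chain or a chain ending in an amine would read on this carbonyl carbon.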